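A few compounds are considered here, and "the series" means these few. Any claim that something is new, unique, unknown or untested is made for them only; others in the source may bear on it.

Measured so far:
Compound 1 `COc1cc(OC)c2sc(-c3ccc(N/C=C\C(=O)c4ccc(OC)c(F)c4)c(C)c3)nc2c1` — 13300 nM
Compound 2 `COc1ccc(C(=O)/C=C\Nc2ccc(-c3nc4cc(OC)c(OC)c(OC)c4s3)cc2)cc1F` — 16500 nM

In a functional assay on MDA-MB-231 cells (Homo sapiens) for antiproliferative activity, read by sulforhodamine B assay, with a stated time of 48 h (a higher number here means a weaker inhibitor, a lower number a stronger inhibitor), compound 2 gives 16500 nM, while compound 1 gives 13300 nM; the gap between the two numbers lies within the usual scatter, so neither compound is set apart from the other. Compound 3 `COc1cc(OC)c2sc(-c3ccc(N/C=C\C(=O)c4ccc(OC)c(F)c4)cc3)nc2c1` is not yet measured. Compared with compound 2, it shows (hydrogen in place of methoxy on an aromatic carbon).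

Within the data shown here, with no step between measured compounds to build on, a change in this assay is expected to be small, with no clear direction beyond the scatter. The step this estimate implies, a 1.3-fold lower number from compound 2 to compound 3 (0.10 log units; within the scatter), is expected to stay within the scatter. Compound 3 is expected to give 13000 nM, with a range from 5000 nM to 35000 nM.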

Compound 3, half-maximal inhibitory concentration: 6700 nM
The estimate for compound 3 lay 1.9-fold (0.29 log units) above the measured number; the measured number falls inside the stated range.
By their numbers in this assay, from the lowest: compounds 3, 1 and 2 (each within the scatter of the next, the first and the last beyond it).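

In this assay, among these compounds, hydrogen in place of the methoxy group ortho to two methoxy groups gives a 2.5-fold lower number from compound 2 to compound 3 (0.39 log units; beyond the scatter) and is the first step to lie beyond the scatter, so this position on the fused ring system does respond to change. Hydrogen in place of methyl on an aromatic carbon gives a 2.0-fold lower number from compound 1 to compound 3 (0.30 log units; within the scatter) and stays within the scatter. No evidence here bears on the reason for either result.

The compounds shown leave open how a fluorine atom, a hydroxyl or an amine at the methoxy position would compare with hydrogen.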